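Nitro in place of hydrogen on compound 2

The compounds below may be only part of what the source reports. "The series", "measured", "known", "first", "only" and "open" are said of these compounds alone.

In a functional assay on KB cells (Homo sapiens) for inhibition, read by MTT assay, with a stated time of 24 h, tested at 0.1 ug/mL (on this read-out lower numbers stand for less inhibition of growth and higher numbers for more inhibition of growth at the one concentration tested), compound 1 (`O=C(CCCCC1CCSS1)Nc1ccc([N+](=O)[O-])c(C(F)(F)F)c1`) gives 4.5% at the single concentration tested. Compound 2 (`O=C(CCCCC(S)CCS)Nc1cccc(C(F)(F)F)c1`) gives 8.41% in the same test, a number within the scatter of compound 1, so the two cannot be ranked. Compound 3 (`O=C(CCCCC(S)CCS)Nc1ccc([N+](=O)[O-])c(C(F)(F)F)c1`) follows from compound 2 by one change, nitro in place of hydrogen on an aromatic carbon. Going by the values given here, no measured pair isolates this change, so the data hold no direct step for it. Compound 1 also carries nitro but differs elsewhere too, and compound 1 at 4.5% lies within the scatter of compound 2 at 8.41%. On that thin basis, the expectation in this assay is a number 0.4 percentage points lower from compound 2 to compound 3 (within the scatter) with no step beyond the scatter in either direction. Compound 3 is estimated at 8% with an expected range from 2% to 18% on repeated measurement.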

Compound 3, percent growth inhibition at one concentration: "not active" (no number reported)
For compound 3 the study gives words and no number, and the estimate cannot be compared.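

Going by these compounds alone, compound 3 is reported in words only in this assay, with no number, so no step from compound 2 can be read. The compounds shown leave open how nitro in place of hydrogen alone shifts growth inhibition. No available evidence bears on this result.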